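Swapping the Phenol Ester: Benzoate to Cyanophenylsulfonyl

This account rests on a few compounds, and the source may have more. Where it says the series, first, only, none or still open, it means among the compounds named here.

Compound 1 `CC(=O)Oc1ccc(-c2cncn2C2CCN(C(=O)c3ccc(Cl)c(C(F)(F)F)c3)CC2)cc1`: in an assay on HEK293 cells for antagonist activity at P2X purinoceptor 7 (Homo sapiens), read by fluorescence, with a stated time of 2 h (a lower number here means a stronger inhibitor, a higher number a weaker inhibitor), compound 1 gives > 10000 nM, which is a limit of the assay and not a number.
Compound 2 `O=C(Oc1ccc(-c2cncn2C2CCN(C(=O)c3ccc(Cl)c(C(F)(F)F)c3)CC2)cc1)c1ccccc1`: in this assay compound 2 gives > 10000 nM, again a limit of the assay rather than a number.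

Compounds 1 and 2 share one core and differ only in the ester on the phenol oxygen: phenyl in place of methyl on a carbonyl carbon. The step that the two limits leave unreadable from compound 1 to compound 2 cannot be read, because of the limit of > 10000 nM in this assay, at which 2 of the 2 values shown sit. Compound 2 therefore stands at the limit, and no real number for it is known.

Compound 3 `N#Cc1cccc(S(=O)(=O)Oc2ccc(-c3cncn3C3CCN(C(=O)c4ccc(Cl)c(C(F)(F)F)c4)CC3)cc2)c1` carries a third ester at the same place. The change is (3-cyanophenyl)sulfonyl in place of benzoyl on an oxygen on an aromatic ring. For the measured compounds named here, no measured step bears on a change of this kind; the only measured step is itself unreadable, so the direction and size of any shift are open. With both known compounds at the limit, compound 3 is expected to sit near the limit too, estimated at 15000 nM within 3000 nM to 60000 nM. The expected step that the limit leaves unreadable from compound 2 to compound 3 is thus essentially none beyond the scatter.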

Compound 3, half-maximal inhibitory concentration: 73 nM
Compound 3: the middle estimate sits 210-fold (2.31 log units) above what was measured, outside the stated range (below it).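

In this assay, the group on an oxygen on an aromatic ring turns out to matter greatly: (3-cyanophenyl)sulfonyl in place of benzoyl gives an at least 130-fold lower number from compound 2 to compound 3 (2.13 log units; beyond the scatter), and (3-cyanophenyl)sulfonyl in place of acetyl gives an at least 130-fold lower number from compound 1 to compound 3 (2.13 log units; beyond the scatter). The two carboxylic esters showed nothing of this, since neither gave a real number and the step between them cannot be read, whereas compound 3 gives the series its first true measurement on this shared core. Both new steps are minimum sizes rather than exact ones, since the starting point of each is only a limit of the assay: the limit of > 10000 nM in this assay, at which 2 of the 3 values shown sit.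

The change brings in a sulfonyl link and a nitrile on the ring together, so compound 1, compound 2 and compound 3 cannot show which of the two carries the step. A plain phenylsulfonyl group without the nitrile and a 3-cyanobenzoyl group would pull these two parts apart, and a small methylsulfonyl group would show whether the aromatic ring on the sulfonyl is needed at all.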